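This account rests on a few compounds, and the source may have more. Where it says the series, first, only, none or still open, it means among the compounds named here.

Measured compounds:
- Compound 1, `CC[C@@H](Nc1c(C#N)c(-c2ccc(-c3ccc(F)cc3)cc2)nc2cnccc12)C(N)=O`: 2.7
- Compound 2, `CCOc1ccccc1-c1ccc(-c2nc3cnccc3c(N[C@H](CC)C(=O)NS(C)(=O)=O)c2C#N)cc1`: 2.2

Both numbers come from a physicochemical assay for lipophilicity, read by HPLC, at pH 7.5; on this read-out lower numbers stand for lower lipophilicity and higher numbers for higher lipophilicity. Compound 1 stands at the top of the two values shown: in this assay compound 1 gives 2.7, and compound 2 gives 2.2, a number that lies below it by more than the usual scatter of repeated runs. The two compounds share a core and differ in several places at once, so nothing about any single group can be read from that gap.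

The unmeasured compound 3, `CC[C@@H](Nc1c(C#N)c(-c2ccc(-c3ccccc3Cl)cc2)nc2cnccc12)C(N)=O`, differs from compound 1 in just one place: 2-chlorophenyl in place of 4-fluorophenyl on an aromatic carbon. The new group sits on an aromatic carbon of a six-membered aromatic ring of carbon only, para to a large group. Within the data shown here, no pair of measured compounds shows this exact change, so the size of the step has to be judged without a direct precedent. A modest upward shift in this assay is expected, of about a number 0.40 log units higher from compound 1 to compound 3 (beyond the scatter), somewhat beyond the scatter but not large. Compound 3 is therefore estimated at 3.1, within a range from 2.7 to 3.5.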

Compound 3, distribution coefficient: 2.9
Estimate against measurement, compound 3: 0.20 log units above; low and high end bracket the measured number.
By their numbers in this assay, from the lowest: compound 2; then compounds 1 and 3 (each within the scatter of the next).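

Among these compounds, replacing 4-fluorophenyl with 2-chlorophenyl gives the first comparison here in which only one place changes, and in this assay the result is a number 0.20 log units higher from compound 1 to compound 3 (within the scatter). At this position, then, the two groups cannot be told apart on this read-out, although they carry different halogens and the halogen sits at a different numbered place in each group's name. The groups also match in what can be counted, with the same number of heavy atoms, no hydrogen-bond donors or acceptors and no net charge, but no measurement here explains the result.

On these data alone, whether an amine or a carboxylic acid on this outer phenyl ring would produce a step beyond the usual scatter stays open, since a single swap between two halogen-bearing phenyl groups says little about groups of a different kind. Among the compounds shown here, compound 2 differs from compound 1 and from compound 3 in more than one place, so no step involving it can be read, and what each of its groups contributes on its own also remains unknown.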